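Replacing a cyano group on selenium with trifluoromethyl

The source may hold more compounds than are shown below. What is called first, only, known or untested is meant among the compounds shown, and "the series" means these compounds.

Measured compounds:
Compound 1, `COC(=O)c1ccccc1C(=O)OCCC[Se]C(F)(F)F`, 7700 nM
Compound 2, `CC1=C(CC(=O)OCCC[Se]C#N)c2cc(F)ccc2/C1=C\c1ccc([S+](C)[O-])cc1`, 31300 nM
Compound 3, `COc1ccc2c(c1)c(CC(=O)OCCC[Se]C(F)(F)F)c(C)n2C(=O)c1ccc(Cl)cc1`, 9300 nM

All three were tested in a functional assay on MCF7 cells (Homo sapiens) for cytotoxicity, read by MTT assay, with a stated time of 72 h; a lower number here means a stronger inhibitor, a higher number a weaker inhibitor. Compound 2 has the highest number of the three, so it is the weakest inhibitor shown. Compound 3 gives 9300 nM and compound 1 gives 7700 nM; both of these gaps to compound 2 are beyond the usual scatter. Compound 1 and compound 3 both carry a trifluoromethyl on selenium, while compound 2 carries a cyano there, but they also differ from compound 2 in many other places, so no single change can be read off from them.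

The unmeasured compound 4, `CC1=C(CC(=O)OCCC[Se]C(F)(F)F)c2cc(F)ccc2/C1=C\c1ccc([S+](C)[O-])cc1`, is compound 2 with one change: trifluoromethyl in place of cyano on a selenium. For the measured compounds named here, no measured pair shows this exact change alone. The expectation is a modest step toward a lower number, not certain to exceed the scatter, and the step from compound 2 to compound 4 is estimated as a 2.4-fold lower number from compound 2 to compound 4 (0.38 log units; beyond the scatter). Compound 4 is therefore expected to give about 13000 nM, with a range from 4500 nM to 38000 nM.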

Compound 4, half-maximal inhibitory concentration: 19600 nM
Estimate against measurement, compound 4: 1.5-fold (0.18 log units) below; the measured number falls inside the stated range.
By their numbers in this assay, from the lowest: compounds 1 and 3 (each within the scatter of the next); then compounds 4 and 2 (each within the scatter of the next).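

Until this pair, the group on selenium could be compared only between compounds that also differed in many other places. Here it is the single difference, and in this assay trifluoromethyl in place of cyano on a selenium gives a 1.6-fold lower number from compound 2 to compound 4 (0.20 log units; within the scatter), so on this core the two groups cannot be told apart in this cell test. No measurement shown bears on why this is so.

Going by these compounds, whether a different group on this selenium, such as pentafluoroethyl or a longer chain, would shift the number beyond the scatter remains open. Also open, on these data alone, is whether the same exchange would give a similar result on the core of compound 1 or the core of compound 3, since each appears here only with trifluoromethyl.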